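A few compounds are considered here, and "the series" means these few. Any claim that something is new, unique, unknown or untested is made for them only; others in the source may bear on it.

Values measured in an in vitro ADME assay on microsomes from liver (Homo sapiens) for metabolic stability; on this read-out higher numbers stand for fast clearance and lower numbers for slow clearance:

- compound 1 `CC(C)Nc1nccc(-c2c[nH]nc2C2CCCCO2)n1` gives 0.021 mL/min/kg
- compound 2 `C[C@H](CC(=O)O)Nc1nccc(-c2c[nH]nc2-c2ccc(Cl)cc2)n1` gives < 0.006 mL/min/kg
- compound 3 `OC1CCCC(c2n[nH]cc2-c2ccnc(NC3CCCC3)n2)C1` gives 0.015 mL/min/kg

Of these three, only compound 2 is reported as a limit of the assay and not as a number, at < 0.006 mL/min/kg. The set as a whole reads: the limit of < 0.006 mL/min/kg in this assay, at which 1 of the 3 values shown sits. Compounds 1 and 3 both return numbers.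

Compound 4 `Clc1ccc(-c2n[nH]cc2-c2ccnc(NC3CCCCC3)n2)cc1` has not yet been measured. It differs from compound 2 as follows: cyclohexyl in place of 1-(carboxymethyl)ethyl on a nitrogen on an aromatic ring. In short, cyclohexyl stands in place of 1-(carboxymethyl)ethyl on a nitrogen on an aromatic ring.

Within the data shown here, no two measured compounds differ in one place alone, so the expectation rests on indirect evidence. Neither of the two compounds with numbers carries 1-(carboxymethyl)ethyl: compound 1 gives 0.021 mL/min/kg and compound 3 gives 0.015 mL/min/kg. Both also differ from compound 4 elsewhere, so this is only a loose guide. A rise in this assay beyond the scatter therefore seems likely. The expected step of an at least 5.0-fold higher number from compound 2 to compound 4 (0.69 log units; beyond the scatter) points towards faster clearance. For compound 4 the estimated value is 0.03 mL/min/kg, with an expected range from 0.012 mL/min/kg to 0.07 mL/min/kg.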

Compound 4, clearance: 0.156 mL/min/kg
Beside the measured number, compound 4's estimate is 5.2-fold (0.72 log units) below it; measured number outside the range, above it.
By their numbers in this assay, from the lowest: compounds 3 and 1 (each within the scatter of the next); then compound 4. At a limit, below all of these: compound 2.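

In this assay, among these compounds, compound 2 and compound 4 form the first pair in the set that differs in one place alone, and the group on a nitrogen on an aromatic ring turns out to have a large effect on the read-out: an at least 26-fold higher number from compound 2 to compound 4 (1.41 log units; beyond the scatter), with cyclohexyl in place of 1-(carboxymethyl)ethyl. Among the compounds shown here, the single change removes a chain with its hydrogen-bond donor, hydrogen-bond acceptor and defined stereocentre, and brings in a ring of carbon only, so the step belongs to all of these differences taken together. The step has only a lower bound, not a full size, because compound 2 gives a limit of the assay and not a number: the limit of < 0.006 mL/min/kg in this assay, at which 1 of the 4 values shown sits.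

The compounds shown leave open whether the step follows the arrival of the cyclohexyl ring or the departure of the carboxylic acid, as no compound here separates the two. From the compounds shown here alone, an ester or an amide on the same chain, or a cyclohexyl ring bearing a carboxylic acid, would bear on that question, and how such groups would read in this assay remains unknown.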